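This account rests on a few compounds, and the source may have more. Where it says the series, first, only, none or still open, it means among the compounds named here.

Measured in a functional assay on A-375 cells (Homo sapiens) for inhibition, read by MTT assay, with a stated time of 120 h; on this read-out higher numbers stand for weaker inhibition and lower numbers for stronger inhibition:
- compound 1 `C/C(=C\c1ccc(NC(=O)Nc2ccc(Cl)c(C(F)(F)F)c2)cc1)C(=O)NC(C)c1ccccc1`: > 50000 nM
- compound 2 `CNC(=O)/C(C)=C/c1ccc(NC(=O)Nc2ccc(Cl)c(C(F)(F)F)c2)cc1`: > 50000 nM
- compound 3 `CC(NC(=O)CCc1ccc(NC(=O)Nc2ccc(Cl)c(C(F)(F)F)c2)cc1)c1ccccc1`: > 50000 nM

All three entries are limits of the assay, not numbers. Compound 3 therefore has no exact position, and it shares its place with the other two: the limit of > 50000 nM in this assay, at which 3 of the 3 values shown sit.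

The next structure is compound 4 `CNC(=O)CCc1ccc(NC(=O)Nc2ccc(Cl)c(C(F)(F)F)c2)cc1`. The change is methyl in place of 1-phenylethyl on an amide-type nitrogen, which in words is methyl in place of 1-phenylethyl on an amide-type nitrogen.

The same swap has been measured once, as a step that the two limits leave unreadable from compound 1 to compound 2. That step has neither a readable size nor a direction. Compound 2, which already carries the methyl, gives > 50000 nM, again a limit. On this thin evidence, no step beyond the usual scatter is expected in this assay, and a further limit is the likeliest report.

The expected change is a number no higher from compound 3 to compound 4 (the limit leaves the size open). For compound 4 the estimated value is 50000 nM, with an expected range of 20000 nM to 100000 nM.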

Compound 4, half-maximal inhibitory concentration: 25200 nM
The estimate for compound 4 lay 2.0-fold (0.30 log units) above the measured number; low and high end bracket the measured number.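

In this assay, among the compounds shown here, compound 4 is the first compound to give a number instead of a limit, while the others stay at that limit: the limit of > 50000 nM in this assay, at which 3 of the 4 values shown sit. Putting methyl in place of 1-phenylethyl on the amide-type nitrogen gives an at least 1.9-fold lower number from compound 3 to compound 4 (0.29 log units; that floor lies within the scatter), and putting 2-(methylcarbamoyl)ethyl in place of 2-(methylcarbamoyl)prop-1-en-1-yl gives an at least 1.9-fold lower number from compound 2 to compound 4 (0.29 log units; that floor lies within the scatter). These are floors rather than full sizes, and the step between the two remaining compounds cannot be read, so the same swap has a readable floor only on the saturated chain.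

Going by these compounds, how far the number would move with an ethyl group or a plain hydrogen on that nitrogen remains open. So does the effect of a carboxylic acid in place of the amide.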